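This account rests on a few compounds, and the source may have more. Where it says the series, first, only, none or still open, it means among the compounds named here.

Of the compounds shown here, two built on one shared core have been tested in a functional assay on OVCAR-3 cells (Homo sapiens) for cytotoxicity, read by MTT assay, with a stated time of 72 h; a higher number here means a weaker inhibitor, a lower number a stronger inhibitor. Compound 1 `CCCCCN(CCCCC)c1nc2c(ncn2-c2ccccc2)c(=O)n1-c1ccc(Cl)cc1` carries a dipentylamino group and a 4-chlorophenyl group on that core. In this assay compound 1 gives > 100000 nM, which is a limit of the assay and not a measured number. Going by the values given here, compound 2 `CCNc1nc2c(ncn2-c2ccccc2)c(=O)n1-c1ccccc1` differs from compound 1 in more than one place, so no single step connects the two. In this assay compound 2 gives > 100000 nM, again a limit rather than a number. Where compound 1 stands is thus plain: it sits at the limit of > 100000 nM in this assay, at which 2 of the 2 values shown sit.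

Compound 3 `O=c1c2ncn(-c3ccccc3)c2nc(NCc2ccccc2)n1-c1ccc(Cl)cc1` has not yet been measured. It differs from compound 1 by benzylamino in place of dipentylamino on an aromatic carbon; in words, benzylamino in place of dipentylamino on an aromatic carbon. Among the compounds with values here, with no measured step to lean on, and both known values sitting at a limit, the expected step is a number no higher from compound 1 to compound 3 (the limit leaves the size open), that is, none beyond the usual scatter. Compound 3 is therefore expected to give 100000 nM, within a range from 30000 nM to 300000 nM, and most probably the assay will once more report only a limit.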

Compound 3, half-maximal inhibitory concentration: 46700 nM
Compound 3: the middle estimate sits 2.1-fold (0.33 log units) above what was measured, within the range that was stated.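

At this position the change does shift the read-out: in this assay, putting benzylamino in place of dipentylamino on the aromatic carbon gives an at least 2.1-fold lower number from compound 1 to compound 3 (0.33 log units; beyond the scatter). Going by these compounds alone, compound 3 is the first compound here to give a real number instead of a limit, so this position can move the result off the ceiling of the assay, and the size of the step remains only a lower bound: the limit of > 100000 nM in this assay, at which 2 of the 3 values shown sit. The change is not a single clean one, however, as benzylamino brings in a six-membered aromatic ring of carbon only and a hydrogen-bond donor, neither of which dipentylamino has, and it also has fewer heavy atoms.

The compounds shown therefore leave open which of these differences matters, whether it is the aromatic ring, the hydrogen on the linking nitrogen or the smaller size of the group. A cyclohexylmethylamino group would keep a ring without its aromatic character, and a benzyl(methyl)amino group would keep the aromatic ring without that hydrogen, so each would help to separate these possibilities.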